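The compounds below may be only part of what the source reports. "The series", "measured", "known", "first", "only" and "open" are said of these compounds alone.

Measured so far:
Compound 1 `O=C(O)c1ccc(C(=O)/C(=C\c2ccc(F)c([N+](=O)[O-])c2)SCc2ccc(Cl)cc2)cc1` gives 50000 nM in a functional assay on DU-145 cells (Homo sapiens) for inhibition, read by trypan blue exclusion, with a stated time of 96 h; on this read-out higher numbers stand for weaker inhibition of growth and lower numbers for stronger inhibition of growth.
Compound 2 `CSc1ccc(/C=C(/SCc2ccc(Cl)cc2)C(=O)c2ccc(Cl)cc2)cc1` gives 25000 nM in this assay.
Compound 3 `O=C(O)c1ccc(/C=C(/SCc2ccc(Cl)cc2)C(=O)c2ccc(C(=O)O)cc2)cc1` gives only a limit of the assay, > 100000 nM, in this assay.

Compound 3 thus stands at the very edge of what the numbers shown can say: it sits at the limit of > 100000 nM in this assay, at which 1 of the 3 values shown sits, so its true number is unknown. Compound 4 `CSc1ccc(/C=C(/SCc2ccc(Cl)cc2)C(=O)c2ccc(C(=O)O)cc2)cc1` differs from it in one place: methylsulfanyl in place of carboxy on an aromatic carbon. Among the measured compounds shown here, only one measured step touches this ring, an at least 2.0-fold higher number from compound 1 to compound 3 (0.30 log units; that floor lies within the scatter), and it brought in the carboxy from a different group, so it bears on the present change only loosely. Taking the carboxy out again is expected to move the number downward, toward stronger inhibition, with a step of about an at least 2.0-fold lower number from compound 3 to compound 4 (0.30 log units; that floor lies within the scatter). Compound 4 is therefore estimated at 50000 nM, within a range from 15000 nM to 150000 nM.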

Compound 4, concentration for 50% growth inhibition: > 100000 nM
Compound 4 gave a limit, no number; the forecaster's own chance of this, stated with the estimate: 35%; at least 2.0-fold (0.30 log units) between middle value and limit.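

Compound 4 also gives only a limit of the assay, as compound 3 does, so the step between them cannot be read and methylsulfanyl in place of carboxy on this ring yields no readable number: the limit of > 100000 nM in this assay, at which 2 of the 4 values shown sit.

The other carboxy remains in compound 4, and carboxy in place of chloro gives an at least 4.0-fold higher number from compound 2 to compound 4 (0.60 log units; beyond the scatter). The comparison with the other ring changed gives an at least 2.0-fold higher number from compound 1 to compound 4 (0.30 log units; that floor lies within the scatter).

Going by these compounds, the true numbers of compound 3 and compound 4 remain unknown. Also open, on these data alone, is whether an amine or a methyl ester in place of the remaining carboxy would give a readable value.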